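Trifluoromethyl for Ethynyl: An Expected Outcome

The compounds below may be only part of what the source reports. "The series", "measured", "known", "first", "only" and "open" are said of these compounds alone.

Three compounds have been measured in a functional assay on NCI-H1975 cells (Homo sapiens) for antiproliferative activity, read by MTT assay, with a stated time of 72 h; on this read-out lower numbers stand for stronger inhibition and higher numbers for weaker inhibition:

Compound 1 `COc1cc2ncnc(Nc3ccccc3)c2cc1OCCCCC(=O)Nc1ccc(S(N)(=O)=O)cc1` gives 14100 nM.
Compound 2 `NS(=O)(=O)c1ccc(NC(=S)Nc2ccc3ncnc(Nc4ccc(F)c(Cl)c4)c3c2)cc1` gives 15800 nM.
Compound 3 `C#Cc1cccc(Nc2ncnc3ccc(NC(=S)Nc4ccc(S(N)(=O)=O)cc4)cc23)c1` gives 13400 nM.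

Compound 3 has the lowest of the three numbers, yet its gaps to compound 1 and compound 2 both lie within the scatter, so the three cannot be ranked. Compound 4 `NS(=O)(=O)c1ccc(NC(=S)Nc2ccc3ncnc(Nc4cccc(C(F)(F)F)c4)c3c2)cc1` differs from compound 3 by trifluoromethyl in place of ethynyl on an aromatic carbon. Going by the values given here, the only step that touches the same position is a 1.2-fold lower number from compound 2 to compound 3 (0.07 log units; within the scatter), a swap of the whole aromatic group that left the number unchanged. Among the compounds with values here, no measured step shows the trifluoromethyl itself. The step of a 1.1-fold higher number from compound 3 to compound 4 (0.05 log units; within the scatter) is therefore expected to stay within the scatter. Compound 4 is estimated at 15000 nM, within 6500 nM to 35000 nM.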

Compound 4, half-maximal inhibitory concentration: 7590 nM
Compound 4: middle estimate off by 2.0-fold (0.30 log units), on the high side; low and high end bracket the measured number.
By their numbers in this assay, from the lowest: compounds 4, 3, 1 and 2 (each within the scatter of the next, the first and the last beyond it).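

In this assay, going by these compounds alone, the step of a 2.1-fold lower number from compound 2 to compound 4 (0.32 log units; beyond the scatter) is modest, yet it is the first step on this aromatic group to pass beyond the scatter. The step of a 1.8-fold lower number from compound 3 to compound 4 (0.25 log units; within the scatter) stays within the scatter, so trifluoromethyl and ethynyl cannot be told apart at this position. No measurement shown here offers an explanation for either step.

The compounds shown leave open how an amine or a carboxylic acid would compare with trifluoromethyl on this same aromatic carbon.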